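Chalcone amide series: cytotoxicity notes toward compound 4

A few compounds are considered here, and "the series" means these few. Any claim that something is new, unique, unknown or untested is made for them only; others in the source may bear on it.

The series shares one core, shown for compound 1 as `COC(=O)c1cc(-c2cccc(NC(=O)c3ccc(/C=C/C(=O)c4ccccc4)cc3)c2)on1`. In an ADME assay on Vero cells (Chlorocebus sabaeus) for cytotoxicity, read by MTT assay, with a stated time of 72 h (on this read-out lower numbers stand for higher toxicity in this test and higher numbers for lower toxicity in this test), compound 1 gives > 50 ug/mL, which is a limit of the assay and not a number. Compound 2 `COC(=O)c1cc(-c2cccc(NC(=O)c3ccc(/C=C/C(=O)c4cc(OC)c(OC)c(OC)c4)cc3)c2)on1` gives > 50 ug/mL in this assay, again a limit. Compound 3 `COC(=O)c1cc(-c2cccc(NC(=O)c3ccc(/C=C/C(=O)c4ccc(Br)cc4)cc3)c2)on1` gives > 20 ug/mL in this assay, also a limit. The step that the two limits leave unreadable from compound 1 to compound 2 is therefore not readable, and neither is a step that the two limits leave unreadable from compound 1 to compound 3 nor a step that the two limits leave unreadable from compound 2 to compound 3. What the measured set shows is the limit of > 50 ug/mL in this assay, at which 2 of the 3 values shown sit, together with the limit of > 20 ug/mL in this assay, at which 1 of the 3 values shown sits.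

Compound 4 `COC(=O)c1cc(-c2cccc(NC(=O)c3ccc(/C=C/C(=O)c4ccc(F)cc4F)cc3)c2)on1` has not yet been measured. It differs from compound 1 by 2,4-difluorophenyl in place of phenyl on a carbonyl carbon. Among the compounds with values here, no measured step reads out for this kind of change; the nearest comparisons are the steps from compound 1 to compound 2 and from compound 1 to compound 3, each replacing the same phenyl on the carbonyl carbon, and each hidden by limits. Within the data shown here, since every value in this assay so far sits at a limit, no shift beyond the scatter is expected for compound 4, and the step that the limit leaves unreadable from compound 1 to compound 4 is estimated to be essentially flat. Compound 4 is expected to give 60 ug/mL, within 30 ug/mL to 150 ug/mL, most probably reported once more as a limit.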

Compound 4, half-maximal cytotoxic concentration: > 40 ug/mL
Compound 4 gave a limit, no number (the forecaster's own chance of this, stated with the estimate: 80%); the middle value does not contradict the limit.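

In this assay compound 4 gives > 40 ug/mL, a limit of the assay and not a number. Within the data shown here, no step from compound 1, compound 2 or compound 3 to compound 4 can be read; all four values are limits. The compounds shown leave open whether any replacement of the phenyl on the carbonyl carbon changes the half-maximal cytotoxic concentration in this assay at all.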